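A few compounds are considered here, and "the series" means these few. Any claim that something is new, unique, unknown or untested is made for them only; others in the source may bear on it.

Among the compounds with values here, compound 2 `CCCC[C@H]1CC[C@H](OC(=O)N[C@@H](CC(C)C)C(=O)N[C@H](C=O)C[C@@H]2CCNC2=O)CC1` is the only member of this set with a single number in an ADME assay on HEK-293T cells (Homo sapiens) for cytotoxicity, with a stated time of 72 h (on this read-out lower numbers stand for higher toxicity in this test and higher numbers for lower toxicity in this test), where compound 2 gives 55000 nM. Compound 1 `CC(C)C[C@H](NC(=O)OC1CCC(C)(C)CC1)C(=O)N[C@H](C=O)C[C@@H]1CCNC1=O` reaches only a limit in this assay, > 100000 nM, the limit named in the limit of > 100000 nM in this assay, at which 1 of the 3 values shown sits. Compound 3 `CC(C)C[C@H](NC(=O)OCC1CCC(F)(F)CC1)C(=O)N[C@H](C=O)C[C@@H]1CCNC1=O` has no result in this assay, recorded as "not determined" (no result reported); "not determined" (no result reported) (2 entries). Within the data shown here, the one measured step, an at least 1.8-fold lower number from compound 1 to compound 2 (0.25 log units; that floor lies within the scatter), is therefore a floor rather than a measured size. Compound 4 `CC(C)C[C@H](NC(=O)OCc1cccc(F)c1)C(=O)N[C@H](C=O)C[C@@H]1CCNC1=O` carries 3-fluorobenzyl in place of 4-butylcyclohexyl on an oxygen next to a carbonyl group. That earlier step concerned a different change on the same oxygen and gives no direction for this one. For compound 4 a step of a 1.3-fold higher number from compound 2 to compound 4 (0.10 log units; within the scatter) is therefore expected, not beyond the scatter. Compound 4 is estimated at 70000 nM, within 25000 nM to 200000 nM.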

Compound 4, half-maximal cytotoxic concentration: > 100000 nM
Compound 4 was reported as a limit (the forecaster's own chance of this, stated with the estimate: 40%); middle value at least 1.4-fold (0.15 log units) away from the limit.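

Within the data shown here, replacing the ring on this oxygen next to a carbonyl group with 3-fluorobenzyl gives an at least 1.8-fold higher number from compound 2 to compound 4 (0.25 log units; that floor lies within the scatter), so an aromatic ring here is seen for the first time, and the size of the step remains a floor. Compound 4 joins compound 1 at the top of the range in this assay, and the step between those two cannot be read: the limit of > 100000 nM in this assay, at which 2 of the 4 values shown sit.

As far as these compounds go, how far compound 1 and compound 4 actually lie from compound 2 stays open. So does whether a benzyl group carrying an amine or a carboxylic acid would give a single number.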